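Swapping the Ring on the Carbonyl of Compound 3

A few compounds are considered here, and "the series" means these few. Any claim that something is new, unique, unknown or untested is made for them only; others in the source may bear on it.

In a functional assay on isolated protein for inhibition of Glucose-dependent insulinotropic receptor (Rattus norvegicus), read by HTRF and cAMP accumulation (a lower number here means that less compound is needed, a higher number that more compound is needed for the effect), three close relatives of a shared core have been measured. Compound 1 `Cc1nc(S(C)(=O)=O)ccc1Oc1ncnc(OC2CCN(C(=O)OC(C)(C)CF)CC2)c1F` gives 138 nM, compound 2 `Cc1nc(S(C)(=O)=O)ccc1Oc1ncnc(OC2CCN(C(=O)OC(C)F)CC2)c1F` gives 315 nM, and compound 3 `CCC1(OC(=O)N2CCC(Oc3ncnc(Oc4ccc(S(C)(=O)=O)nc4C)c3F)CC2)CC1` gives 333 nM, the top of the three numbers, although a 1.1-fold higher number from compound 2 to compound 3 (0.02 log units; within the scatter) lies within the scatter while a 2.4-fold higher number from compound 1 to compound 3 (0.38 log units; beyond the scatter) is a modest rise. Compound 4 `Cc1nc(S(C)(=O)=O)ccc1Oc1ncnc(OC2CCN(C(=O)c3noc(C(C)C)n3)CC2)c1F` differs from compound 3 in one place: a group of 8 heavy atoms (5 carbon, 2 nitrogen, 1 oxygen; one five-membered aromatic ring with 3 hetero atoms) in place of a group of 6 heavy atoms (5 carbon, 1 oxygen; one three-membered non-aromatic ring of carbon only), on a carbonyl carbon. The measured steps all swap groups on an oxygen next to a carbonyl group and never touch the carbonyl carbon itself, so none of them tests this kind of change; their modest sizes only suggest that variation near this end is tolerated. The expected step is a 1.1-fold higher number from compound 3 to compound 4 (0.02 log units; within the scatter). Compound 4 is estimated at 350 nM, between 100 nM and 1200 nM.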

Compound 4, half-maximal effective concentration: 176 nM
Compound 4: middle estimate off by 2.0-fold (0.30 log units), on the high side, within the range that was stated.
By their numbers in this assay, from the lowest: compounds 1, 4, 2 and 3 (each within the scatter of the next, the first and the last beyond it).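

Within the data shown here, the 5-isopropyl-1,2,4-oxadiazol-3-yl group is the first change here made directly on the carbonyl carbon, and it stays within the scatter of all three earlier compounds: a 1.9-fold lower number from compound 3 to compound 4 (0.28 log units; within the scatter) and a 1.8-fold lower number from compound 2 to compound 4 (0.25 log units; within the scatter) and a 1.3-fold higher number from compound 1 to compound 4 (0.11 log units; within the scatter). So at this position, an aromatic ring can take the place of the oxygen-linked groups without a step beyond the scatter.

Going by these compounds, whether a phenyl ring or a 5-tert-butyl-1,2,4-oxadiazol-3-yl group on this carbonyl carbon would give a similar number stays open. No other data are available here to explain how this swap is tolerated.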